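The compounds below may be only part of what the source reports. "The series", "measured", "known", "first", "only" and "open" are said of these compounds alone.

Measured so far in a functional assay on MCF7 cells (Homo sapiens) for cytotoxicity, read by MTT assay, with a stated time of 24 h; a higher number here means a weaker inhibitor, a lower number a stronger inhibitor:
- compound 1 `Cn1c(-c2ccc(NC(=O)CSc3nc4ccccc4o3)cc2)nc(-c2ccccc2)c1-c1ccccc1` gives 11.2 ug/mL
- compound 2 `Cn1c(-c2ccc(NC(=O)CSC3=NCCS3)cc2)nc(-c2ccccc2)c1-c1ccccc1` gives 26.7 ug/mL
- compound 3 `Cn1ccnc1SCC(=O)Nc1ccc(-c2nc(-c3ccccc3)c(-c3ccccc3)n2C)cc1` gives 46.5 ug/mL

Compound 3 carries the highest number of the three in this assay. Its distance from compound 2 lies within the scatter, so the two cannot be ordered, while the step of a 4.2-fold higher number from compound 1 to compound 3 (0.62 log units; beyond the scatter) lies beyond it.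

Compound 4 `CN(C)/C=C/N1CCN(CC(=O)Nc2ccc(-c3nc(-c4ccccc4)c(-c4ccccc4)n3C)cc2)CC1` differs from compound 3 at the saturated chain carbon bound to the carbonyl carbon: 4-(2-(dimethylamino)ethenyl)piperazin-1-yl in place of (1-methyl-1H-imidazol-2-yl)sulfanyl on a saturated chain carbon bound to a carbonyl carbon. The measured steps all swap one ring on the sulfur for another and were modest at most: a 2.4-fold higher number from compound 1 to compound 2 (0.38 log units; beyond the scatter), a 4.2-fold higher number from compound 1 to compound 3 (0.62 log units; beyond the scatter) and a 1.7-fold higher number from compound 2 to compound 3 (0.24 log units; within the scatter). None of them removes the sulfur or brings in a six-membered non-aromatic ring, so they bear on the new change only loosely, showing that this end of the molecule has so far moved the number by modest amounts.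

The expectation for compound 4 is therefore a number close to that of compound 3, with no step beyond the scatter in either direction, an expected step of a 1.2-fold lower number from compound 3 to compound 4 (0.07 log units; within the scatter). The estimated value for compound 4 is 40 ug/mL, within a range from 15 ug/mL to 120 ug/mL.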

Compound 4, half-maximal inhibitory concentration: 80 ug/mL
Compound 4: the middle estimate sits 2.0-fold (0.30 log units) below what was measured, and the stated range covers the measured number.
By their numbers in this assay, from the lowest: compound 1; then compounds 2, 3 and 4 (each within the scatter of the next, the first and the last beyond it).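

Putting 4-(2-(dimethylamino)ethenyl)piperazin-1-yl in place of (1-methyl-1H-imidazol-2-yl)sulfanyl on the saturated chain carbon bound to a carbonyl carbon gives a step within the scatter in this assay (a 1.7-fold higher number from compound 3 to compound 4 (0.24 log units; within the scatter)), so a sulfur-free group with more heavy atoms cannot be told apart from the group it replaces. Set against the other two compounds, the same group gives steps beyond the scatter (a 3.0-fold higher number from compound 2 to compound 4 (0.48 log units; beyond the scatter); a 7.1-fold higher number from compound 1 to compound 4 (0.85 log units; beyond the scatter)), the second being the widest gap in this set, so the choice of group here has moved the number only modestly so far. No measurement is available to explain these differences.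

Still open, on these data alone, is whether the 2-(dimethylamino)ethenyl part matters, which a simple 4-methylpiperazin-1-yl or a morpholin-4-yl group could test. Also open, as far as these compounds go, is how a plain dimethylamino group would read at this carbon.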